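The source may report more compounds than this note shows. Statements on the series, on what has been measured and on what is new or still open speak of the compounds shown alone.

Three compounds share one core and differ only in the aryl group attached to an amide-type nitrogen. In a functional assay on HepG2 cells (Homo sapiens) for antiproliferative activity, read by MTT assay (a lower number here means a stronger inhibitor, a higher number a weaker inhibitor), compound 2 `CNC(=O)c1ccc(Oc2cccc(NC(=S)Nc3ccc(F)c(F)c3)c2)nc1` gives 26700 nM, the highest of the three numbers. Compound 1 `CNC(=O)c1ccc(Oc2cccc(NC(=S)Nc3ccc(Br)c(C(F)(F)F)c3)c2)nc1` gives 8530 nM and compound 3 `CNC(=O)c1ccc(Oc2cccc(NC(=S)Nc3cc(C(F)(F)F)cc(C(F)(F)F)c3)c2)nc1` gives 4550 nM, both lower than compound 2 by more than the usual scatter. Compound 4 `CNC(=O)c1ccc(Oc2cccc(NC(=S)Nc3ccc(OC)cc3)c2)nc1` has not been measured; it differs from compound 2 in one place: 4-methoxyphenyl in place of 3,4-difluorophenyl on an amide-type nitrogen. Within the data shown here, no measured pair shows this change, so its direction cannot be read from the data. The step from compound 2 to compound 4 is expected to be a 1.1-fold higher number from compound 2 to compound 4 (0.05 log units; within the scatter), not beyond the scatter. Compound 4 is therefore estimated at 30000 nM, with a range from 10000 nM to 90000 nM.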

Compound 4, half-maximal inhibitory concentration: 85300 nM
Estimate against measurement, compound 4: 2.8-fold (0.45 log units) below, within the range that was stated.
By their numbers in this assay, from the lowest: compounds 3 and 1 (each within the scatter of the next); then compound 2; then compound 4.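

In this assay, the aryl group on this amide-type nitrogen matters even when its size stays the same: 4-methoxyphenyl in place of 3,4-difluorophenyl gives a 3.2-fold higher number from compound 2 to compound 4 (0.50 log units; beyond the scatter). Among these compounds, this is the first single change that can be read directly, and it shows that a weaker result can come from this swap. No measurement at hand explains the rise. The step removes two fluorines and adds a methoxy group together, so the compounds shown leave open which part drives it, and how a plain phenyl group would compare.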